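Aryl swap on the amide nitrogen, compound 2 to compound 3

The source may hold more compounds than are shown below. What is called first, only, known or untested is meant among the compounds shown, and "the series" means these compounds.

Two compounds carry numbers in an assay on isolated protein for inhibition of histone deacetylase 4 (Homo sapiens), with a stated time of 1 h; on this read-out lower numbers stand for stronger inhibition and higher numbers for weaker inhibition. Compound 2 `O=C(COc1ccc2cc(/C=C3/SC(=O)NC3=O)ccc2c1)Nc1cccc(C(F)(F)F)c1` gives 2500 nM and compound 1 `CCOc1ccc2nc(NC(=O)COc3ccc4cc(/C=C5/SC(=O)NC5=O)ccc4c3)sc2c1` gives 3600 nM; the two values lie within the scatter of each other, so neither stands apart. Compound 3 `Cc1ccc(NC(=O)COc2ccc3cc(/C=C4/SC(=O)NC4=O)ccc3c2)cc1Cl` remains unmeasured. Its change from compound 2 is 3-chloro-4-methylphenyl in place of 3-(trifluoromethyl)phenyl on an amide-type nitrogen. For the measured compounds named here, no measured pair shows a step of this kind, so there is no measured step to lean on. The expected step is no change at the digits printed from compound 2 to compound 3 (within the scatter), no larger than the scatter and in no set direction. Compound 3 is therefore estimated at 2500 nM, with a range of 1000 nM to 6300 nM.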

Compound 3, half-maximal inhibitory concentration: 1100 nM
The estimate for compound 3 lay 2.3-fold (0.36 log units) above the measured number; the measured number falls inside the stated range.
By their numbers in this assay, from the lowest: compound 3; then compounds 2 and 1 (each within the scatter of the next).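

For the compounds shown here, with the shared core held constant, the aryl group on the amide nitrogen responds in this assay: 3-chloro-4-methylphenyl in place of 3-(trifluoromethyl)phenyl gives a 2.3-fold lower number from compound 2 to compound 3 (0.36 log units; beyond the scatter) and is the only measured step. This position can therefore shift the read-out beyond the scatter, although the step is modest. No available data explain the step.

On these data alone, whether the chlorine or the methyl carries the step stays open; a phenyl bearing only one of them would separate the two. As far as these compounds go, how an amine or a carboxylic acid on this aryl ring would read is also open.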